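This account rests on a few compounds, and the source may have more. Where it says the series, first, only, none or still open, it means among the compounds named here.

Measured so far in an ADME assay on MT4 cells (Homo sapiens) for cytotoxicity, read by MTT assay, with a stated time of 4 days; a lower number here means that less compound is tolerated, a higher number that more compound is tolerated:

compound 1, `CCOC(=O)c1cnc(N2CCN(Cc3ccc(C#N)cc3)CC2)nc1Oc1c(C)cc(-c2ccc(C#N)cc2)cc1C` — in this assay compound 1 gives > 125000 nM, a limit of the assay and not a number.
compound 2, `CCOC(=O)c1cnc(N2CCN(Cc3ccccc3C(F)(F)F)CC2)nc1Oc1c(C)cc(-c2ccc(C#N)cc2)cc1C` — in this assay compound 2 gives > 125000 nM, again only a limit.
compound 3, `CCOC(=O)c1cnc(N2CCN(Cc3ccc(C(=O)OC)cc3)CC2)nc1Oc1c(C)cc(-c2ccc(C#N)cc2)cc1C` — in this assay compound 3 gives > 125000 nM, again only a limit.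

Compound 1 therefore stands on no number at all; its cytotoxic concentration is known only as a limit, and the same holds for the two further values, as summed up by the limit of > 125000 nM in this assay, at which 3 of the 3 values shown sit. The measured steps that touch the same place on the shared core are a step that the two limits leave unreadable from compound 1 to compound 2, a step that the two limits leave unreadable from compound 1 to compound 3 and a step that the two limits leave unreadable from compound 2 to compound 3; none of them has a readable size, so they neither show a change beyond the scatter nor rule one out.

Compound 4, `CCOC(=O)c1cnc(N2CCN(Cc3cccc(C(N)=O)c3)CC2)nc1Oc1c(C)cc(-c2ccc(C#N)cc2)cc1C`, carries the change (3-carbamoylphenyl in place of 4-cyanophenyl on a saturated chain carbon bound to an amine nitrogen in a ring). The three measured exchanges at this position all returned the limit, so no step beyond the scatter is expected here either; the expected step is a step that the limit leaves unreadable from compound 1 to compound 4, which is no more than the scatter. Compound 4 is estimated at 150000 nM, with a range of 60000 nM to 400000 nM, and the result is most likely again only a limit.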

Compound 4, half-maximal cytotoxic concentration: 14800 nM
For compound 4 the middle estimate is 10-fold (1.01 log units) above the measured one; the measured number lies below the stated range.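

In this assay, the position on a saturated chain carbon bound to an amine nitrogen in a ring proves able to change the read-out: 3-carbamoylphenyl in place of 4-cyanophenyl gives an at least 8.4-fold lower number from compound 1 to compound 4 (0.92 log units; beyond the scatter), while the other two exchanges give an at least 8.4-fold lower number from compound 3 to compound 4 (0.92 log units; beyond the scatter) and an at least 8.4-fold lower number from compound 2 to compound 4 (0.92 log units; beyond the scatter). For the compounds shown here, compound 4 gives 14800 nM, the first readable number, so the earlier uniform result at this position does not extend to 3-carbamoylphenyl. The three steps give only a minimum size, and the steps among compounds 1, 2 and 3 still cannot be read, because those compounds remain at a limit of the assay: the limit of > 125000 nM in this assay, at which 3 of the 4 values shown sit.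

The compounds shown do not separate the effect of the carbamoyl group from that of its place on the phenyl ring, as 3-carbamoylphenyl differs from 4-cyanophenyl in both the group and its ring position. They also leave open whether a carboxylic acid or an aminomethyl group on the same phenyl ring would give a readable number like that of compound 4 or stay at the limit.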